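Swapping the aryl ether of compound 1 for an aryl thioether

The compounds below may be only part of what the source reports. "The series", "measured", "known", "first", "only" and "open" are said of these compounds alone.

Measured compounds:
compound 1, `Nc1cc(N)c2nc(-c3ccccc3)c(Oc3ccc(Cl)c(Cl)c3)nc2c1`: 10200 nM
compound 2, `Nc1cc(N)c2nc(-c3ccccc3)c(NCc3ccc(Cl)c(Cl)c3)nc2c1`: 1580 nM
compound 3, `CCOC(=O)[C@H](CCC(=O)O)NC(=O)c1ccc(Sc2nc3cc(N)cc(N)c3nc2-c2ccccc2)cc1`: 7940 nM

Of the compounds shown here, three sharing one core have been tested in a functional assay on MDA-MB-231 cells (Homo sapiens) for inhibition, read by sulforhodamine B assay, with a stated time of 48 h; on this read-out lower numbers stand for stronger inhibition of growth and higher numbers for weaker inhibition of growth. Compound 1 stands at the highest number of the three. Compound 3 sits closest to it, and the gap between them lies within the scatter, so the two cannot be told apart. Compound 2 lies furthest from compound 1, at a number well beyond the scatter, so compound 2 is the one of the three that inhibits growth more strongly than compound 1 on this read-out.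

Compound 4, `Nc1cc(N)c2nc(-c3ccccc3)c(Sc3ccc(F)cc3)nc2c1`, has not yet been measured in this assay. It differs from compound 1 in one place: (4-fluorophenyl)sulfanyl in place of 3,4-dichlorophenoxy on an aromatic carbon. The change thus keeps an aromatic ring attached through a single linking atom at the same position on the core, while the halogen pattern on that ring and the nature of the linking atom both shift.

Compound 3, which also carries an arylsulfanyl group at this position, gives a number within the scatter of compound 1, so no large step is expected. The step from compound 1 to compound 4 is estimated at a 1.7-fold lower number from compound 1 to compound 4 (0.23 log units; within the scatter), a small shift towards stronger inhibition that may well fall inside the scatter. Compound 4 is therefore expected to give about 6000 nM in this assay, with a plausible range from 2000 nM to 18000 nM.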

Compound 4, concentration for 50% growth inhibition: 17400 nM
Compound 4: the middle estimate sits 2.9-fold (0.46 log units) below what was measured, and the stated range covers the measured number.
By their numbers in this assay, from the lowest: compound 2; then compounds 3, 1 and 4 (each within the scatter of the next, the first and the last beyond it).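

Within the data shown here, the exchange of 3,4-dichlorophenoxy for (4-fluorophenyl)sulfanyl on this aromatic carbon, next to the ring nitrogen, amounts to a 1.7-fold higher number from compound 1 to compound 4 (0.23 log units; within the scatter) in this assay and is the first step that can be read at this position. It shows that the linking oxygen and the two chlorine atoms can be exchanged together for a linking sulfur and a single fluorine without a difference that can be told from the scatter on this read-out. The two changes were made in one step, however, so the result cannot be divided between the linking atom and the halogen pattern, and nothing measured here offers an explanation for the result.

Going by these compounds, a 4-fluorophenoxy group or a (3,4-dichlorophenyl)sulfanyl group at this position would separate those two changes, and how either would read remains open. Also open, on these data alone, is whether a group with no halogen, such as plain phenylsulfanyl, or a piperazine ring attached at the same carbon would give a number that stands apart from those of compound 1 and compound 4 in this assay on the shared core.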